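Replacing 3,4-Dimethylphenyl with 1H-Indol-6-yl

A few compounds are considered here, and "the series" means these few. Any claim that something is new, unique, unknown or untested is made for them only; others in the source may bear on it.

In a functional assay on B16-F0 cells (Mus musculus) for inhibition, read by CCK-8 assay, with a stated time of 48 h (on this read-out higher numbers stand for weaker inhibition and lower numbers for stronger inhibition), compound 1 (`COc1cc(-c2ccnc3cc(-c4ccc(F)cc4)nn23)cc(OC)c1OC`) gives 4540 nM, while compound 2 (`COc1cc(-c2ccnc3cc(-c4ccc(C)c(C)c4)nn23)cc(OC)c1OC`) gives 391 nM, the lower of the two numbers and so the stronger inhibition. Compound 3 (`COc1cc(-c2ccnc3cc(-c4ccc5cc[nH]c5c4)nn23)cc(OC)c1OC`) keeps the shared core and differs from compound 2 at the same place: 1H-indol-6-yl in place of 3,4-dimethylphenyl on an aromatic carbon. Among the measured compounds shown here, only one measured step bears on this exchange, a 12-fold lower number from compound 1 to compound 2 (1.06 log units; beyond the scatter), and it is large, so a change at this place has already shifted the number well beyond the scatter. That step involved different groups and cannot settle the direction here, leaving only a slight lean toward a lower number. The expected change is a 2.6-fold lower number from compound 2 to compound 3 (0.42 log units; beyond the scatter), though the uncertainty is wide. The estimate for compound 3 is 150 nM, with an expected range from 25 nM to 800 nM.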

Compound 3, half-maximal inhibitory concentration: 55 nM
The estimate for compound 3 lay 2.7-fold (0.44 log units) above the measured number; low and high end bracket the measured number.
By their numbers in this assay, from the lowest: compound 3; then compound 2; then compound 1.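

In this assay, exchanging 3,4-dimethylphenyl for 1H-indol-6-yl gives a 7.1-fold lower number from compound 2 to compound 3 (0.85 log units; beyond the scatter), which shows that this place on the shared core accepts a fused two-ring group and that the number can fall further than the earlier pair showed. Measured against the 4-fluorophenyl group, the same 1H-indol-6-yl group gives an 83-fold lower number from compound 1 to compound 3 (1.92 log units; beyond the scatter), so the choice of group at this one place spans a wide range of inhibition. No measurement is available to explain why the number falls.

The compounds shown leave open whether the gain follows the hydrogen-bond donor of 1H-indol-6-yl, its five-membered ring or the larger group as a whole, since all three enter together. Going by these compounds, how a group carrying an amine or a carboxylic acid would read at this place also remains open.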